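Replacing the Terminal Amino Group with Propyl

The source may hold more compounds than are shown below. What is called first, only, known or untested is meant among the compounds shown, and "the series" means these compounds.

Of the compounds shown here, three have been measured in a functional assay on the whole organism for antagonist activity, with Mus musculus as the target; a lower number here means that less compound is needed, a higher number that more compound is needed for the effect. Compound 1 `NCC(=O)NCC(=O)Nc1ccc([N+](=O)[O-])cc1C(=O)c1ccccc1Cl` gives 2.64 mg/kg in this assay. Compound 2 `NC(C(=O)NCC(=O)Nc1ccc(Cl)cc1C(=O)c1ccccc1)c1ccccc1` gives 28 mg/kg. Compound 3 `CN(C(=O)CNC(=O)CN)c1ccc(Cl)cc1C(=O)c1ccccc1Cl` gives 0.58 mg/kg, the lowest of the three numbers; its gap to compound 1 and its larger gap to compound 2 both lie beyond the scatter, so compound 3 needs the least compound of the three. Compound 4 `CCCCC(=O)NCC(=O)N(C)c1ccc(Cl)cc1C(=O)c1ccccc1Cl` has not yet been measured. It differs from compound 3 in one place: propyl in place of amino on a saturated chain carbon bound to a carbonyl carbon. Among the compounds with values here, each of the three measured compounds carries the amino that leaves here, so no measured pair shows this change directly, and the expectation rests on compound 3 alone. The step from compound 3 is expected to run toward a higher number, that is, more compound needed, and to reach beyond the scatter; the expected size is a 4.3-fold higher number from compound 3 to compound 4 (0.63 log units; beyond the scatter). In this assay compound 4 is estimated at 2.5 mg/kg, with a range from 0.6 mg/kg to 10 mg/kg.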

Compound 4, dose for half-maximal effect: 1.3 mg/kg
Compound 4: the middle estimate sits 1.9-fold (0.28 log units) above what was measured; the measured number falls inside the stated range.
By their numbers in this assay, from the lowest: compound 3; then compound 4; then compound 1; then compound 2.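

The earlier compounds shown here all carry the amino group, so they could not show whether the effect in this assay depends on it at this saturated chain carbon bound to a carbonyl carbon. Propyl in place of amino moves the number only modestly (a 2.2-fold higher number from compound 3 to compound 4 (0.35 log units; beyond the scatter)), a real shift that stays beyond the scatter but does not abolish the effect, so the amino is not required for it in this series. Nothing available explains the size or direction of this step.

On these data alone, it remains open how a hydroxyl group, a carboxylic acid or a longer chain would behave at this place. Also open, as far as these compounds go, is whether the same change would give a step of similar size on the cores of compound 1 and compound 2.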